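Series notes: aryl replacement at the amide-type nitrogen

A few compounds are considered here, and "the series" means these few. Any claim that something is new, unique, unknown or untested is made for them only; others in the source may bear on it.

Compound 1 `COc1cc2cc(Oc3ccc(NC(=O)Nc4ccccc4)cc3)c(C)nc2cc1OC` is the reference point of the pair measured so far. Within the data shown here, in a functional assay on HCT-116 cells (Homo sapiens) for inhibition, read by sulforhodamine B assay, with a stated time of 48 h, tested at 10 uM (on this read-out lower numbers stand for a stronger effect and higher numbers for a weaker effect at the one concentration tested), compound 1 gives 42.6%, which stands at one end of the two numbers in hand, though the gap to the only other number is within the usual scatter. Compound 2 `COc1cc2cc(Oc3ccc(NC(=O)Nc4ccc(C(F)(F)F)cc4)cc3)c(C)nc2cc1OC` carries trifluoromethyl in place of hydrogen on an aromatic carbon; in this assay compound 2 gives 47.2%, and the step of a number 4.6 percentage points higher from compound 1 to compound 2 (within the scatter) lies within the scatter.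

Compound 3 `COc1cc2cc(Oc3ccc(NC(=O)Nc4ccc(Cl)c(C(F)(F)F)c4)cc3)c(C)nc2cc1OC` has not yet been measured. Its difference from the reference is 4-chloro-3-(trifluoromethyl)phenyl in place of phenyl on an amide-type nitrogen. Among the measured compounds shown here, the one measured step that bears on this change already places trifluoromethyl on that ring and reads a number 4.6 percentage points higher from compound 1 to compound 2 (within the scatter), within the scatter; the added chlorine has no precedent among the measured compounds. Compound 3 is therefore expected to sit close to its parent, with the step of a number 2.4 percentage points higher from compound 1 to compound 3 (within the scatter) expected to stay within the scatter. In this assay compound 3 is estimated at 45%, with a range from 30% to 60%.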

Compound 3, a percentage reported as activity, at one concentration (the size of the read-out at that concentration, not a potency): -87.3%
Compound 3: middle estimate off by 132.3 percentage points, on the high side; the measured number lies below the stated range.
By their numbers in this assay, from the lowest: compound 3; then compounds 1 and 2 (each within the scatter of the next).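

In this assay, the aryl group on the amide-type nitrogen turns out to be a position where the read-out can shift far: a number 129.9 percentage points lower from compound 1 to compound 3 (beyond the scatter), a size of change that the trifluoromethyl step alone, a number 4.6 percentage points higher from compound 1 to compound 2 (within the scatter), gave no sign of. The comparison between the two substituted rings, a number 134.5 percentage points lower from compound 2 to compound 3 (beyond the scatter), shows that 4-(trifluoromethyl)phenyl and 4-chloro-3-(trifluoromethyl)phenyl are far from interchangeable here, and this change both brings in chlorine and replaces a 4-(trifluoromethyl) pattern with a 3-(trifluoromethyl) pattern. No measurement in hand accounts for this large change.

The compounds shown do not separate the contribution of the chlorine from that of the trifluoromethyl placement, so it stays open whether 4-chlorophenyl or 3-(trifluoromethyl)phenyl alone would give most of the change or whether it needs both groups on one ring. Also open, as far as these compounds go, is whether the result is specific to chlorine, or whether bromine or a nitrile at the same place on the 3-(trifluoromethyl)phenyl ring would give a similar number.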